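Trimming a Methyl From the Side Chain of Compound 3

The source may hold more compounds than are shown below. What is called first, only, known or untested is meant among the compounds shown, and "the series" means these compounds.

Of the compounds shown here, three sharing one core have been measured in a functional assay on NCI-H460 cells (Homo sapiens) for antiproliferative activity, read by CCK-8 assay, with a stated time of 72 h, tested at 2 uM; on this read-out lower numbers stand for a weaker effect and higher numbers for a stronger effect at the one concentration tested. Compound 1 `Nc1ccccc1NC(=O)c1ccc(CNc2nc(Cl)nc3c2ncn3Cc2ccccc2)cc1` gives 43.8%, compound 2 `COC(CCn1cnc2c(NCc3ccc(C(=O)Nc4ccccc4N)cc3)nc(Cl)nc21)OC` gives 43.7%, and compound 3 `CCC(C)n1cnc2c(NCc3ccc(C(=O)Nc4ccccc4N)cc3)nc(Cl)nc21` gives 47.3%. Compound 3 thus holds the highest of the three numbers, yet its gap to compound 1, a number 3.5 percentage points higher from compound 1 to compound 3 (within the scatter), and its gap to compound 2, a number 3.6 percentage points higher from compound 2 to compound 3 (within the scatter), both lie within the scatter, so no real order among them can be claimed.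

Compound 4 `CCCn1cnc2c(NCc3ccc(C(=O)Nc4ccccc4N)cc3)nc(Cl)nc21` is the next step from compound 3. The change is hydrogen in place of methyl on a saturated chain carbon bound to an aromatic nitrogen and a saturated chain carbon. The two measured steps that touch the same position, the replacement of benzyl or of 3,3-dimethoxypropyl by sec-butyl, moved the read-out only within the scatter despite being much larger changes than the loss of one methyl. In this assay no step beyond the scatter is therefore expected, and the estimated shift is a number 2.3 percentage points lower from compound 3 to compound 4 (within the scatter). Compound 4 is expected to give about 45%, with a range from 35% to 55%.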

Compound 4, a percentage reported as inhibition, at one concentration (the size of the read-out at that concentration, not a potency): 31%
The estimate for compound 4 lay 14 percentage points above the measured number, and the stated range ends above it.
By their numbers in this assay, from the lowest: compound 4; then compounds 2, 1 and 3 (each within the scatter of the next).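

In this assay this position turns out to respond to a small change: trimming sec-butyl to propyl gives a number 16.3 percentage points lower from compound 3 to compound 4 (beyond the scatter) even though benzyl, 3,3-dimethoxypropyl and sec-butyl all lie within the scatter of one another. The larger replacements that end in propyl also go beyond the scatter, with a number 12.7 percentage points lower from compound 2 to compound 4 (beyond the scatter) for the loss of dimethoxymethyl and a number 12.8 percentage points lower from compound 1 to compound 4 (beyond the scatter) for ethyl in place of phenyl, so among these four compounds it is propyl that stands apart, and the number of atoms removed does not set the size of a step. Nothing at hand explains why this group stands apart.

The compounds shown leave open whether the lower number belongs to propyl alone or to unbranched chains more widely. Isopropyl, ethyl or n-butyl on the same aromatic nitrogen would begin to separate these two readings.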